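Benzylamine sulfonamides: dropping the bromine from compound 2

The source may hold more compounds than are shown below. What is called first, only, known or untested is meant among the compounds shown, and "the series" means these compounds.

Measured compounds:
compound 1 `O=S(=O)(NCCNCc1cccc2ccccc12)c1cc(C(F)(F)F)cc(C(F)(F)F)c1` gives 18000 nM
compound 2 `O=S(=O)(NCCCCNCc1ccc(Br)cc1)c1cc(C(F)(F)F)cc(C(F)(F)F)c1` gives 1500 nM
compound 3 `COc1ccc(CNCCCNS(=O)(=O)c2cc(C(F)(F)F)cc(C(F)(F)F)c2)cc1OC` gives 1900 nM

In a functional assay on MCF7 cells (Homo sapiens) for inhibition, read by MTT assay, with a stated time of 72 h (on this read-out lower numbers stand for stronger inhibition of growth and higher numbers for weaker inhibition of growth), compound 2 gives the lowest number of the three. Compound 3 stands so close to it that the two cannot be told apart within the scatter, whereas compound 1 sits well beyond the scatter with a far weaker result. Compound 2 therefore stands at the favourable end of the measured set, but not alone there.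

Compound 4 `O=S(=O)(NCCCNCc1ccccc1)c1cc(C(F)(F)F)cc(C(F)(F)F)c1` has not yet been measured. It differs from compound 2 in one place: benzylamino in place of ((4-bromobenzyl)amino)methyl on a saturated chain carbon, three bonds along the chain from a sulfonamide nitrogen. Within the data shown here, the set holds no pair of measured compounds that differ in one place, so no measured step guides this change directly; only the spread between compound 2, compound 3 and compound 1 hints at what such changes can do. The loss of the bromine and the shortening of the link are expected to cost some activity in this assay, a modest step upward in the number, close to the edge of the scatter, expressed as a 2.7-fold higher number from compound 2 to compound 4 (0.43 log units; beyond the scatter). Compound 4 is estimated at 4000 nM, with a range from 1500 nM to 12000 nM.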

Compound 4, concentration for 50% growth inhibition: 3000 nM
Estimate against measurement, compound 4: 1.3-fold (0.12 log units) above, within the range that was stated.
By their numbers in this assay, from the lowest: compounds 2, 3 and 4 (each within the scatter of the next); then compound 1.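

In this assay, benzylamino in place of ((4-bromobenzyl)amino)methyl on the saturated chain carbon gives a 2.0-fold higher number from compound 2 to compound 4 (0.30 log units; within the scatter) and so does not separate the two compounds. Phenyl in place of 3,4-dimethoxyphenyl on a saturated chain carbon bound to an amine nitrogen gives a 1.6-fold higher number from compound 3 to compound 4 (0.20 log units; within the scatter) and likewise does not separate them. These are the first single-place comparisons in the set, and neither change moves the read-out beyond the scatter, though no measurement shown bears on the reason for this.

As far as these compounds go, it stays open whether a nitrile or a carboxylic acid on the phenyl group would shift the number beyond the scatter. The compounds shown also leave open what a methyl group on the amine nitrogen would do.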